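The compounds below may be only part of what the source reports. "The series", "measured", "known", "first", "only" and "open" are said of these compounds alone.

Measured so far:
compound 1 `NS(=O)(=O)c1cccc(-c2nc(C(c3ccc(F)cc3)c3ccc(F)cc3)sc2CC(=O)O)c1` — 140 nM
compound 2 `Nc1cc(-c2nc(C(c3ccc(F)cc3)c3ccc(F)cc3)sc2CC(=O)O)cc(F)n1` — 220 nM

In an in vitro assay on HEK385-7 cells for displacement of a labelled ligand from prostaglandin D2 receptor 2 (Homo sapiens) (on this read-out higher numbers stand for weaker inhibition and lower numbers for stronger inhibition), compound 2 gives 220 nM, the higher of the two numbers, and compound 1 gives 140 nM; the step of a 1.6-fold higher number from compound 1 to compound 2 (0.20 log units; within the scatter) lies within the scatter, so the two compounds cannot be ordered. Compound 3 `Cc1cc(-c2nc(C(c3ccc(F)cc3)c3ccc(F)cc3)sc2CC(=O)O)cnc1N` differs from compound 2 by 6-amino-5-methylpyridin-3-yl in place of 2-amino-6-fluoropyridin-4-yl on an aromatic carbon. For the measured compounds named here, the only step measured at this position is the swap from compound 1 to compound 2, and it stayed within the scatter; no step beyond the scatter is therefore expected in this assay for this further aryl swap. Compound 3 is expected to give about 220 nM, range 90 nM to 550 nM. The expected step is no change at the digits printed from compound 2 to compound 3 (within the scatter).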

Compound 3, half-maximal inhibitory concentration: 880 nM
Estimate against measurement, compound 3: 4.0-fold (0.60 log units) below; the measured number lies above the stated range.
By their numbers in this assay, from the lowest: compounds 1 and 2 (each within the scatter of the next); then compound 3.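

In this assay, this position proves sensitive to the choice of aryl group: a 4.0-fold higher number from compound 2 to compound 3 (0.60 log units; beyond the scatter) and a 6.3-fold higher number from compound 1 to compound 3 (0.80 log units; beyond the scatter) both lie beyond the scatter, unlike the earlier swap. 2-Amino-6-fluoropyridin-4-yl and 6-amino-5-methylpyridin-3-yl have matching counts of heavy atoms, donors and acceptors, yet they separate here, so those counts alone do not settle the outcome. Nothing available explains the shift. Still open, from the compounds shown here alone, is whether the methyl group or the ring attachment carries the step; 6-aminopyridin-3-yl, lacking the methyl, would separate the two.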